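The compounds below may be only part of what the source reports. "The series", "measured", "known", "first", "only" and "open" are said of these compounds alone.

Measured so far:
compound 1 `O=C(/C=C/c1ccc2c(c1)B(O)OC2)c1ccc(Br)cc1`: 9500 nM
compound 2 `O=C(/C=C/c1ccc2c(c1)B(O)OC2)c1ccc(I)cc1`: 14900 nM
compound 3 `O=C(/C=C/c1ccc2c(c1)B(O)OC2)c1cccc(F)c1`: 3000 nM

In a functional assay on MDA-MB-231 cells (Homo sapiens) for cytotoxicity, read by MTT assay, with a stated time of 48 h (a lower number here means a stronger inhibitor, a higher number a weaker inhibitor), compound 3 gives the lowest number of the three, with a 3.2-fold lower number from compound 1 to compound 3 (0.50 log units; beyond the scatter) and a 5.0-fold lower number from compound 2 to compound 3 (0.70 log units; beyond the scatter) both beyond the scatter, while a 1.6-fold higher number from compound 1 to compound 2 (0.20 log units; within the scatter) stays within it. Compound 4 `COCOc1cccc(C(=O)/C=C/c2ccc3c(c2)B(O)OC3)c1` differs from compound 3 by methoxymethoxy in place of fluoro on an aromatic carbon. For the measured compounds named here, no measured step exchanges a halogen for a methoxymethoxy group, so the bearing of the series on this change is indirect: the only steps seen swap one halogen for another on the aryl ketone ring, one within the scatter and two of modest size. The expected outcome is therefore a step of a 1.2-fold higher number from compound 3 to compound 4 (0.07 log units; within the scatter), with no firm direction. Compound 4 is estimated at 3500 nM, with a range of 1200 nM to 10000 nM.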

Compound 4, half-maximal inhibitory concentration: 4500 nM
Beside the measured number, compound 4's estimate is 1.3-fold (0.11 log units) below it; the measured number falls inside the stated range.
By their numbers in this assay, from the lowest: compounds 3 and 4 (each within the scatter of the next); then compounds 1 and 2 (each within the scatter of the next).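

In this assay the change from fluoro to methoxymethoxy on this aromatic carbon, meta to a large group, gives a small step (a 1.5-fold higher number from compound 3 to compound 4 (0.18 log units; within the scatter)). The earlier compounds carried only halogens on the aryl ketone ring, whereas compound 4 shows that a non-halogen group of 4 heavy atoms, with 2 hydrogen-bond acceptors, can stand here with the number staying within the scatter of compound 3. (Nothing available explains this result). Still open, on these data alone, is whether a free hydroxyl, an amine or a carboxylic acid on this carbon would keep the number as close to compound 3.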